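This account rests on a few compounds, and the source may have more. Where it says the series, first, only, none or still open, it means among the compounds named here.

Measured so far in a functional assay on KBVIN cells (Homo sapiens) for antiproliferative activity, read by sulforhodamine B assay, with a stated time of 3 days; on this read-out higher numbers stand for an effect only at larger amounts of compound and lower numbers for an effect already at smaller amounts
compound 1 `CCCc1ccc(-c2cc(=O)c3c(o2)C(CC)(CC)C(=O)C(CC)=C3O)cc1` gives 12.2 uM
compound 2 `CCC1=C(O)c2c(oc(-c3ccc(C(C)C)cc3)cc2=O)C(CC)(CC)C1=O` gives 1.08 uM
compound 3 `CCC1=C(O)c2c(oc(-c3ccc(C(F)(F)F)cc3)cc2=O)C(CC)(CC)C1=O` gives 10.4 uM

Compound 2 has the lowest number of the three, and its steps to the other two lie beyond the scatter. The compound still to be measured is compound 4 `CCC1=C(O)c2c(oc(-c3ccc(OC(F)(F)F)cc3)cc2=O)C(CC)(CC)C1=O` with trifluoromethoxy in place of isopropyl on an aromatic carbon, para to a large group trifluoromethoxy in place of isopropyl on an aromatic carbon and the rest of the core unchanged. Going by the values given here, no measured compound carries trifluoromethoxy. The nearest guide by name is the trifluoromethyl group of compound 3, so the step that bears most directly is a 9.6-fold higher number from compound 2 to compound 3 (0.98 log units; beyond the scatter) and it sets the likely direction. The step of an 11-fold lower number from compound 1 to compound 2 (1.05 log units; beyond the scatter) points the same way, since propyl also sits well above isopropyl. The step of a 1.2-fold lower number from compound 1 to compound 3 (0.07 log units; within the scatter) shows no separation between the two groups that stand above isopropyl. A higher number is therefore expected, and the estimated step is a 5.6-fold higher number from compound 2 to compound 4 (0.74 log units; beyond the scatter) in this assay with some allowance for trifluoromethoxy not behaving exactly like trifluoromethyl. Three measured groups give little to go on, so the expected range is kept wide. The estimate for compound 4 is 6 uM (expected range 1.5 uM to 15 uM).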

Compound 4, concentration for half-maximal effect: 9.95 uM
The estimate for compound 4 lay 1.7-fold (0.22 log units) below the measured number, within the range that was stated.
By their numbers in this assay, from the lowest: compound 2; then compounds 4, 3 and 1 (each within the scatter of the next).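

Replacing isopropyl with trifluoromethoxy on this aromatic carbon in this assay gives a 9.2-fold higher number from compound 2 to compound 4 (0.96 log units; beyond the scatter), so a third group, and the first here that is attached through oxygen and counted with a hydrogen-bond acceptor, fails to keep the low number of compound 2. Trifluoromethoxy is not separated from either of the other two groups, with a 1.0-fold lower number from compound 3 to compound 4 (0.02 log units; within the scatter) and a 1.2-fold lower number from compound 1 to compound 4 (0.09 log units; within the scatter), so the oxygen link adds nothing measurable relative to trifluoromethyl. Compounds 1, 3 and 4 therefore form a single level within the scatter despite carrying propyl, trifluoromethyl and trifluoromethoxy, and among these four compounds isopropyl alone stands apart from that level.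

No accompanying measurement bears on what sets isopropyl apart from the other three groups. As far as these compounds go, whether the low number of compound 2 extends to other branched groups at this place, such as tert-butyl or cyclopropyl, stays open, as does where a smaller methoxy or ethyl group would fall relative to the level shared by compounds 1, 3 and 4.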